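Swapping Hydroxy for Nitro on an Aromatic Carbon

The source may hold more compounds than are shown below. What is called first, only, known or untested is meant among the compounds shown, and "the series" means these compounds.

In a functional assay on HT-29 cells (Homo sapiens) for cytotoxicity, read by sulforhodamine B assay, with a stated time of 72 h (on this read-out higher numbers stand for weaker inhibition and lower numbers for stronger inhibition), compound 1 (`COc1ccc(/C(F)=C(/F)c2cc(OC)c(OC)c(OC)c2)cc1N`) gives 4.5 nM, while compound 2 (`COc1ccc(/C(F)=C(/F)c2cc(OC)c(OC)c(OC)c2)cc1O`) gives 110 nM. Compound 2 therefore holds the higher of the two numbers, which means weaker inhibition. Compound 3 (`COc1ccc(/C(F)=C(/F)c2cc(OC)c(OC)c(OC)c2)cc1[N+](=O)[O-]`) has not yet been measured. It carries nitro in place of hydroxy on an aromatic carbon, ortho to a methoxy group: nitro in place of hydroxy on an aromatic carbon. For the measured compounds named here, only one measured step bears on this carbon, and it is large: a 24-fold higher number from compound 1 to compound 2 (1.39 log units; beyond the scatter). That step shows that the group here can matter, but it involves amino and hydroxy, so it says nothing direct about nitro. Without a measured nitro compound, only a modest change is expected, leaning slightly toward weaker inhibition: a 1.5-fold higher number from compound 2 to compound 3 (0.16 log units; within the scatter). For compound 3 the estimated value is 160 nM, with an expected range from 30 nM to 800 nM.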

Compound 3, half-maximal inhibitory concentration: 1310 nM
Beside the measured number, compound 3's estimate is 8.2-fold (0.91 log units) below it; the whole stated range lies below it.
By their numbers in this assay, from the lowest: compound 1; then compound 2; then compound 3.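

Nitro gives a third outcome on this same aromatic carbon, with a 12-fold higher number from compound 2 to compound 3 (1.08 log units; beyond the scatter) and a 290-fold higher number from compound 1 to compound 3 (2.46 log units; beyond the scatter) in this assay. With the rest of the structure unchanged, swapping this one group therefore moves the number well beyond the scatter in every pair, and the order from strongest to weakest inhibition is amino, hydroxy, nitro. Nothing available explains this order.

The compounds shown leave open where other groups on this carbon, such as a methylamino group, an acetamide or a carboxylic acid, would fall in that order, and whether any of them could match amino. They also leave open whether the same order holds in other cell lines.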